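Swapping the aryl group on a fused triazole-thiadiazole core

This account rests on a few compounds, and the source may have more. Where it says the series, first, only, none or still open, it means among the compounds named here.

In a functional assay on the whole organism (strain Wistar Albino) for inhibition, with Rattus norvegicus as the target, read by paw edema, with a stated time of 1 h, at a dose of 20 mg/kg (on this read-out lower numbers stand for less inhibition and higher numbers for more inhibition at the one dose given (going by the name of the read-out)), compound 1 `COc1ccc2[nH]cc(Cc3nn4c(-c5ccoc5C)nnc4s3)c2c1` gives 16% and compound 2 `COc1ccc(Cl)c(-c2nnc3sc(Cc4c(C)[nH]c5ccc(OC)cc45)nn23)c1` gives 11.3%. Compound 2 has the lower of the two numbers, yet its gap to compound 1 lies within the scatter, so no order between them can be claimed. Compound 3 `COc1ccc2[nH]c(C)c(Cc3nn4c(-c5ccoc5C)nnc4s3)c2c1` differs from compound 2 by 2-methylfuran-3-yl in place of 2-chloro-5-methoxyphenyl on an aromatic carbon. Since compound 3 otherwise closely resembles compound 1, which gave 16%, the step from compound 2 to compound 3 is expected to be a number 3.7 percentage points higher from compound 2 to compound 3 (within the scatter), not beyond the scatter. Compound 3 is therefore estimated to give 15%, within a range from 5% to 27%.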

Compound 3, a percentage reported as inhibition, in the whole organism at one dose (the size of the read-out at that dose, not a potency): 19.7%
Compound 3: the middle estimate sits 4.7 percentage points below what was measured, within the range that was stated.
By their numbers in this assay, from the lowest: compounds 2, 1 and 3 (each within the scatter of the next).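

In this assay, 2-methylfuran-3-yl in place of 2-chloro-5-methoxyphenyl on this aromatic carbon gives a number 8.4 percentage points higher from compound 2 to compound 3 (within the scatter) and so does not separate the two rings at this position. Methyl in place of hydrogen on an aromatic carbon, a change the earlier pair could not isolate, gives a number 3.7 percentage points higher from compound 1 to compound 3 (within the scatter) and likewise shows no separation. Nothing measured here explains either step. On these data alone, whether an amine or a carboxylic acid on this aromatic carbon would reach beyond the scatter in this assay remains open.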